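One Methyl Fewer on a Pair Without Measurable Activity

The source may report more compounds than this note shows. Statements on the series, on what has been measured and on what is new or still open speak of the compounds shown alone.

Compound 1 has the structure `CNc1nc(SC)nc2c1ncn2[C@@H]1C[C@@H](O)[C@H](CO)O1`. In a functional assay on MOLT-4 cells (Homo sapiens) (a lower number here means a stronger inhibitor, a higher number a weaker inhibitor), compound 1 gives > 300 uM, which is a limit of the assay rather than a number. Compound 2 has the structure `CN(C)c1nc(Br)nc2c1ncn2[C@@H]1C[C@@H](O)[C@H](CO)O1`. In this assay compound 2 gives > 300 uM, again only a limit. Compound 2 therefore stands nowhere in particular on the numbers shown: both values sit at the limit of > 300 uM in this assay, at which 2 of the 2 values shown sit, so neither compound can be ranked against the other.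

Compound 3, with the structure `CNc1nc(Br)nc2c1ncn2[C@@H]1C[C@@H](O)[C@H](CO)O1`, differs from compound 2 in one place: hydrogen in place of methyl on a nitrogen on an aromatic ring, or hydrogen in place of methyl on a nitrogen on an aromatic ring. For the measured compounds named here, no step between measured compounds has been recorded, so the expected step from compound 2 to compound 3 is estimated as a step that the limit leaves unreadable from compound 2 to compound 3, with no change beyond the scatter anticipated. Compound 3 is expected to give about 400 uM. For compound 3 the range is estimated to run from 100 uM to 2000 uM.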

Compound 3, concentration for 50% inhibition: 177 uM
For compound 3 the middle estimate is 2.3-fold (0.35 log units) above the measured one, and the stated range covers the measured number.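

For the compounds shown here, compound 3 is the first compound here to give a number rather than a limit in this assay, with compound 3 at 177 uM. Trimming dimethylamino to methylamino, with the bromo group kept, gives an at least 1.6-fold lower number from compound 2 to compound 3 (0.22 log units; that floor lies within the scatter), while placing bromo where methylsulfanyl stood on the aromatic carbon, with the methylamino group kept, gives an at least 1.6-fold lower number from compound 1 to compound 3 (0.22 log units; that floor lies within the scatter). Both steps are floors rather than full sizes, and neither is shown to exceed the scatter, because the other end of each step is only a limit: the limit of > 300 uM in this assay, at which 2 of the 3 values shown sit.

The compounds shown leave open whether a plain amino group, with no methyl left on the nitrogen, would lower the number further. They also leave open how chloro would compare with bromo on that aromatic carbon.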